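The source may hold more compounds than are shown below. What is called first, only, known or untested is meant among the compounds shown, and "the series" means these compounds.

Among the compounds with values here, compound 1 `CCC1(Cc2ccccc2)OS(=O)(=O)C=C1OCc1ccccc1Cl` is the one compound with an actual number in an ADME assay on HEL cells (Homo sapiens) for cytotoxicity, with a stated time of 3 days (a lower number here means that less compound is tolerated, a higher number that more compound is tolerated), where compound 1 gives 38000 nM. Compound 2 `CCC1(Cc2ccccc2)OS(=O)(=O)C=C1OC(c1ccccc1)c1ccccc1` returns only a limit in this assay, where compound 2 gives > 200000 nM. That reading is the limit of > 200000 nM in this assay, at which 1 of the 2 values shown sits. Compound 3 `CCC1(Cc2ccccc2)OS(=O)(=O)C=C1OCc1ccc(C)cc1` has not yet been measured in this assay; it differs from compound 1 by 4-methylphenyl in place of 2-chlorophenyl on a saturated chain carbon bound to an oxygen on an unsaturated carbon. Within the data shown here, no step between two measured compounds is available, so the size of the change on going to compound 3 rests on the structural difference alone, and both compounds share the same core. For compound 3 the step is estimated as a 1.4-fold higher number from compound 1 to compound 3 (0.16 log units; within the scatter), a small shift toward more compound tolerated if any, not far beyond the usual scatter. Compound 3 is thus estimated at 55000 nM in this assay, with a range from 20000 nM to 160000 nM.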

Compound 3, half-maximal cytotoxic concentration: 41500 nM
Compound 3: middle estimate off by 1.3-fold (0.12 log units), on the high side; the range from low to high includes it.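

Within the data shown here, the exchange of 2-chlorophenyl for 4-methylphenyl on a saturated chain carbon bound to an oxygen on an unsaturated carbon gives the first step that can be read in this assay: a 1.1-fold higher number from compound 1 to compound 3 (0.04 log units; within the scatter). Compound 1 and compound 3 therefore cannot be told apart in this assay, even though the chlorine is gone, a methyl group has entered and its place on the ring differs. Compound 2 stands as a limit, so no step to it can be read: the limit of > 200000 nM in this assay, at which 1 of the 3 values shown sits.

The compounds shown leave open whether a plain phenyl, a pyridine ring or a phenyl carrying an amine or a carboxylic acid would also read like compound 1 and compound 3 at this position. They also leave open whether the same exchange would read alike on a core carrying a longer chain in place of the ethyl group.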